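Dichlorophenyl for bromophenyl: expected inhibition of compound 4

The compounds below may be only part of what the source reports. "The series", "measured", "known", "first", "only" and "open" are said of these compounds alone.

Compound 1 `CC(C)(C)C1=NN(c2ccc(Br)cc2)C(c2ccc(O)cc2)C1` is tested in an assay on isolated protein for inhibition of protein kinase C zeta type (Homo sapiens), with a stated time of 4 min, tested at 62.5 uM (on this read-out lower numbers stand for less inhibition and higher numbers for more inhibition at the one concentration tested (going by the name of the read-out)), where compound 1 gives 93.2%. Compound 2 `CC(C)(C)C1=NN(c2ccc(C(F)(F)F)cc2)C(c2ccc(O)cc2)C1` gives 94.2%, and compound 3 `CC(C)(C)C1=NN(c2ccc(C(=O)O)cc2)C(c2ccc(O)cc2)C1` gives 47.9%. Of the three numbers, compound 1 stands second highest, with compound 2 nearest (a number 1 percentage points higher from compound 1 to compound 2 (within the scatter)) and compound 3 furthest (a number 45.3 percentage points lower from compound 1 to compound 3 (beyond the scatter)). The step of a number 46.3 percentage points lower from compound 2 to compound 3 (beyond the scatter) shows the same drop from the other halogen-type starting point.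

Compound 4 `CC(C)(C)C1=NN(c2ccc(Cl)cc2Cl)C(c2ccc(O)cc2)C1` differs from compound 1 as follows: 2,4-dichlorophenyl in place of 4-bromophenyl on an amine nitrogen in a ring. The change keeps a halogen-bearing ring on the ring nitrogen. The step that bears on it most directly is a number 1 percentage points higher from compound 1 to compound 2 (within the scatter), within the scatter, where bromo gave way to trifluoromethyl; the large drop a number 45.3 percentage points lower from compound 1 to compound 3 (beyond the scatter) came only with carboxy, which compound 4 does not carry. No step beyond the scatter is therefore expected in this assay for compound 4, in either direction. Compound 4 is estimated at 90%, with a range from 75% to 98%. The expected step is a number 3.2 percentage points lower from compound 1 to compound 4 (within the scatter).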

Compound 4, a percentage reported as inhibition, at one concentration (the size of the read-out at that concentration, not a potency): 71%
Beside the measured number, compound 4's estimate is 19 percentage points above it, and the stated range ends above it.
By their numbers in this assay, from the lowest: compound 3; then compound 4; then compounds 1 and 2 (each within the scatter of the next).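

In this assay the change to 2,4-dichlorophenyl from 4-bromophenyl on the amine nitrogen in a ring gives a number 22.2 percentage points lower from compound 1 to compound 4 (beyond the scatter) with no carboxy present, so a step beyond the scatter at this place no longer belongs to carboxy alone. A halogen-bearing ring here does not by itself keep the number at the level of compound 1 (93.2%), and compound 4 (71%) sits between compound 3 (47.9%) and compound 2 (94.2%). Nothing measured on these compounds accounts for the step.

The change swaps bromine for chlorine and also brings a second chlorine, and this one step cannot separate the two. A monochlorophenyl group, an unsubstituted phenyl or a methoxy-bearing phenyl on the same nitrogen would show how much of the loss follows each part of the change.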